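Three Compounds at the Limit, a Fourth Awaits

The compounds below may be only part of what the source reports. "The series", "measured", "known", "first", "only" and "open" are said of these compounds alone.

Measured so far in an ADME assay on MT4 cells (Homo sapiens) for cytotoxicity (a higher number here means that more compound is tolerated, a lower number that less compound is tolerated), with these results:
- Compound 1 `COC(=O)N[C@H](C(=O)NN(CCC[C@@](O)(Cc1ccccc1)C(=O)N[C@H]1c2ccccc2C[C@H]1O)Cc1ccc(C#N)cc1)C(C)(C)C` gives > 10000 nM as a limit
- Compound 2 `COC(=O)N[C@H](C(=O)NN(CCC[C@@](O)(Cc1ccccc1)C(=O)N[C@H]1c2ccccc2C[C@H]1O)CC(C)C)C(C)(C)C` gives > 10000 nM as a limit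
- Compound 3 `COC(=O)N[C@H](C(=O)NN(CCC[C@@](O)(Cc1ccccc1)C(=O)N[C@H]1c2ccccc2C[C@H]1O)Cc1ccc(OCc2cnc(Cl)s2)cc1)C(C)(C)C` gives > 10000 nM as a limit

Compound 3 stands at > 10000 nM as a limit and not as a number. The whole series shows the limit of > 10000 nM in this assay, at which 3 of the 3 values shown sit, and so no order among the compounds can be read.

The change to compound 4 `COC(=O)N[C@H](C(=O)NN(CCC[C@@](O)(Cc1ccccc1)C(=O)N[C@H]1c2ccccc2C[C@H]1O)Cc1ccc(-c2cccnc2)cc1)C(C)(C)C` is pyridin-3-yl in place of (2-chloro-1,3-thiazol-5-yl)methoxy on an aromatic carbon, counted as pyridin-3-yl in place of (2-chloro-1,3-thiazol-5-yl)methoxy on an aromatic carbon in full.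

The closest evidence is a step that the two limits leave unreadable from compound 1 to compound 3 at an aromatic carbon too, while a step that the two limits leave unreadable from compound 1 to compound 2 bears on it less directly. Neither gives a size to carry over. No step beyond the scatter is expected in this assay because the limit of > 10000 nM in this assay, at which 3 of the 3 values shown sit, covers compound 1, compound 2 and compound 3 alike. The expected outcome is a number no higher from compound 3 to compound 4 (the limit leaves the size open) as an estimate only. For compound 4 the estimated value is 10000 nM with an expected range from 5000 nM to 30000 nM and most likely another limit.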

Compound 4, half-maximal cytotoxic concentration: > 10000 nM
Compound 4 was reported as a limit; the forecaster's own chance of this, stated with the estimate: 85%; the middle value sits exactly at the limit.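

No new step can be read, as the steps from compound 1, compound 2 and compound 3 to compound 4 all end in limits: the limit of > 10000 nM in this assay, at which 4 of the 4 values shown sit.

The compounds shown leave open how these four differ in this assay and at what concentration each would harm the cells.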